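The compounds below may be only part of what the source reports. "The series", "measured", "known", "first", "only" and "open" are said of these compounds alone.

Compound 1 `O=C(NS(=O)(=O)c1ccc(F)cc1)c1ccc(Nc2nc(NC3(c4ccc(Cl)cc4)CC3)nc(OCC(F)(F)F)n2)cc1`: 99%
Compound 2 `CS(=O)(=O)NC(=O)c1ccc(Nc2nc(NC3(c4ccc(Cl)cc4)CC3)nc(OCC(F)(F)F)n2)cc1`: 85%

In an ADME assay on microsomes from liver (Rattus norvegicus) for metabolic stability, with a stated time of 10 min (on this read-out higher numbers stand for a more stable compound and lower numbers for a less stable compound), compound 2 stands lowest of the two numbers; its nearest neighbour is compound 1, and the step of a number 14 percentage points lower from compound 1 to compound 2 (beyond the scatter) already turned on the group carried by the sulfonyl sulfur. Compound 3 `COC(=O)NCCS(=O)(=O)NC(=O)c1ccc(Nc2nc(NC3(c4ccc(Cl)cc4)CC3)nc(OCC(F)(F)F)n2)cc1` carries ((methoxycarbonyl)amino)methyl in place of hydrogen on a saturated chain carbon bound to a sulfonyl sulfur. Going by the values given here, that single measured step is the only guide, and it was modest; no measured pair adds a chain of this kind. The expected step of a number 5 percentage points lower from compound 2 to compound 3 (within the scatter) is therefore small, at most a little downward. Compound 3 is expected at 80%, between 60% and 95%.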

Compound 3, percent of the compound remaining: 100%
Beside the measured number, compound 3's estimate is 20 percentage points below it; measured number above the stated range.
By their numbers in this assay, from the lowest: compound 2; then compounds 1 and 3 (each within the scatter of the next).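

In this assay, adding ((methoxycarbonyl)amino)methyl on the saturated chain carbon bound to the sulfonyl sulfur gives a number 15 percentage points higher from compound 2 to compound 3 (beyond the scatter), so the lower number seen with the methyl group is not a fixed result of losing 4-fluorophenyl. Replacing 4-fluorophenyl with 2-((methoxycarbonyl)amino)ethyl gives a number 1 percentage points higher from compound 1 to compound 3 (within the scatter), so a ring on the sulfonyl sulfur is not needed for a number at this level. Nothing available explains these steps. Going by these compounds, whether a simple amine, a carboxylic acid or a longer chain at this position would behave alike remains open.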